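From Isopropyl to Isobutyl on an Amide Nitrogen

The compounds below may be only part of what the source reports. "The series", "measured", "known", "first", "only" and "open" are said of these compounds alone.

Among the measured compounds shown here, only two compounds have so far been measured in a functional assay on HeLa cells (Homo sapiens) for antiproliferative activity, read by CCK-8 assay, with a stated time of 72 h; a higher number here means a weaker inhibitor of growth, a lower number a stronger inhibitor of growth. Compound 1 (`CCC1C(=O)N(C)c2cnc(-n3ccc4cc(C(=O)NC(C)C)ccc43)nc2N1c1ccn(C)n1`) gives 4350 nM and holds the higher of the two numbers. Compound 2 (`CC[C@@H]1C(=O)N(C)c2cnc(Nc3ccc(S(=O)(=O)NCCCO)cc3)nc2N1C1CCCC1`) gives 357 nM and lies below it by a gap beyond the usual scatter. These two compounds differ in more than one place, however, so their gap cannot be tied to any single change.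

Compound 3 (`CCC1C(=O)N(C)c2cnc(-n3ccc4cc(C(=O)NCC(C)C)ccc43)nc2N1c1ccn(C)n1`) has not yet been measured in this assay and keeps the core of compound 1. For the measured compounds named here, its only difference from compound 1 is isobutyl in place of isopropyl on an amide-type nitrogen. Going by the values given here, no measured pair shows what such a change does, so the expectation rests on this small change and on compound 1 at 4350 nM as the starting point. No step beyond the scatter is expected, and no firm direction can be given. The estimated step of a 1.1-fold lower number from compound 1 to compound 3 (0.04 log units; within the scatter) is therefore small. For compound 3 the expected value is 4000 nM with an estimated range from 1800 nM to 9000 nM in this read-out.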

Compound 3, concentration for 50% growth inhibition: 4970 nM
Beside the measured number, compound 3's estimate is 1.2-fold (0.09 log units) below it; measured number inside the range.
By their numbers in this assay, from the lowest: compound 2; then compounds 1 and 3 (each within the scatter of the next).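

In this assay, among the compounds shown here, placing isobutyl where isopropyl stood on the amide-type nitrogen gives a 1.1-fold higher number from compound 1 to compound 3 (0.06 log units; within the scatter), which is the only step in this set that can be tied to a single place. It shows that, at this nitrogen, going from a group of 3 heavy atoms to one of 4, all carbon and with no ring, leaves the two compounds indistinguishable in this read-out, so this one change does not separate them. No independent measurement bears on why the two compounds read alike.

The compounds shown leave open whether a longer chain, a ring such as cyclohexyl, or a chain ending in an amine or a carboxylic acid on this same nitrogen would give a step beyond the scatter, as isobutyl and isopropyl are the only two groups seen here. They also leave open which feature lies behind the low number of compound 2, at 357 nM, as that compound differs from compound 1 and compound 3 in more than one place, and no single-place series yet links them.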